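Methoxy in place of cyclohexyl: compound 2 to compound 4

The source may report more compounds than this note shows. Statements on the series, on what has been measured and on what is new or still open speak of the compounds shown alone.

Measured so far in a functional assay on MES-SA cells (Homo sapiens) for cytotoxicity, read by luminescence and CellTiter-Glo, with a stated time of 72 h; a lower number here means a stronger inhibitor, a higher number a weaker inhibitor:
compound 1 `CC[C@H](NC(=O)[C@H](COC)NC(=O)c1cc(C)on1)C(=O)N[C@@H](CC(C)C)C(=O)[C@@]1(C)CO1`: 468 nM
compound 2 `COC[C@H](NC(=O)c1cc(C)on1)C(=O)N[C@@H](CC1CCCCC1)C(=O)N[C@@H](CC(C)C)C(=O)[C@@]1(C)CO1`: 353 nM
compound 3 `Cc1cc(C(=O)N[C@@H](CC(C)C)C(=O)N[C@@H](CCc2ccccc2)C(=O)N[C@@H](CC(C)C)C(=O)[C@@]2(C)CO2)n[nH]1`: > 1000 nM, a limit of the assay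

Compound 2 stands at the low end of the two numbers shown, although a 1.3-fold lower number from compound 1 to compound 2 (0.12 log units; within the scatter) is within the scatter. Compound 3 sits at the limit of > 1000 nM in this assay, at which 1 of the 3 values shown sits.

Compound 4 `COC[C@H](NC(=O)c1cc(C)on1)C(=O)N[C@@H](COC)C(=O)N[C@@H](CC(C)C)C(=O)[C@@]1(C)CO1` differs from compound 2 by methoxy in place of cyclohexyl on a saturated chain carbon, two bonds along the chain from an amide-type nitrogen and a carbonyl carbon. For the measured compounds named here, the only measured step at this place is a 1.3-fold lower number from compound 1 to compound 2 (0.12 log units; within the scatter), and it was within the scatter, so it gives no firm direction. The author therefore expects a modest step, a 1.7-fold higher number from compound 2 to compound 4 (0.23 log units; within the scatter), toward a weaker number. For compound 4 the estimate is 600 nM, with a range from 250 nM to 1500 nM.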

Compound 4, half-maximal inhibitory concentration: 145 nM
The estimate for compound 4 lay 4.1-fold (0.62 log units) above the measured number, and the stated range ends above it.
By their numbers in this assay, from the lowest: compound 4; then compounds 2 and 1 (each within the scatter of the next). At a limit, above all of these: compound 3.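

In this assay this position now gives a step beyond the scatter, with a 2.4-fold lower number from compound 2 to compound 4 (0.39 log units; beyond the scatter) and a 3.2-fold lower number from compound 1 to compound 4 (0.51 log units; beyond the scatter) when methoxy is the group on this carbon. Methyl and cyclohexyl had stayed within the scatter of each other, so methoxy is the first group here to stand apart from both. Nothing shown gives a cause for this difference. As far as these compounds go, it remains open whether a hydroxyl group, an amine or a longer chain ending in methoxy would match methoxy at this carbon.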